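Notes on the step from compound 3 to compound 4

This account rests on a few compounds, and the source may have more. Where it says the series, first, only, none or still open, it means among the compounds named here.

Measured in a functional assay on A549 cells (Homo sapiens) for antiproliferative activity, read by MTT assay, with a stated time of 72 h; a lower number here means a stronger inhibitor, a higher number a weaker inhibitor:
- compound 1 `COc1cc(-n2cnc3ccc(-c4ccc(C)cc4F)cc32)cc(OC)c1OC` gives > 10000 nM
- compound 2 `COc1ccc(-c2ccc3ncn(-c4cc(OC)c(OC)c(OC)c4)c3c2)cc1O` gives 200 nM
- compound 3 `COc1cc(-n2cnc3ccc(-c4cccc(F)c4)cc32)cc(OC)c1OC` gives 5270 nM

The entry for compound 1 is a limit of the assay, not a number.

Compound 3 holds the higher of the two actual numbers, and its nearest neighbour is set by a 26-fold higher number from compound 2 to compound 3 (1.42 log units; beyond the scatter) on the scale.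

The next compound is compound 4 `COc1cc(-n2cnc3ccc(-c4ccc(C)cc4)cc32)cc(OC)c1OC`, with 4-methylphenyl in place of 3-fluorophenyl on an aromatic carbon.

Two large steps, an at least 50-fold lower number from compound 1 to compound 2 (1.69 log units; beyond the scatter) and a 26-fold higher number from compound 2 to compound 3 (1.42 log units; beyond the scatter), each bring in or remove the 3-hydroxy-4-methoxyphenyl, a group that compound 4 does not carry. Going by the values given here, the one step without that group, an at least 1.8-fold lower number from compound 1 to compound 3 (0.27 log units; that floor lies within the scatter), has a floor within the scatter and is the closest guide here. No large change is therefore expected in this assay, and the number should stay in the weak range, with at most a slight rise. The expected change is a 1.3-fold higher number from compound 3 to compound 4 (0.12 log units; within the scatter), which is not estimated to lie beyond the scatter. Compound 4 may also return only a limit. The estimate for compound 4 is 7000 nM, with an expected range from 2500 nM to 20000 nM in this measurement.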

Compound 4, half-maximal inhibitory concentration: 1940 nM
The estimate for compound 4 lay 3.6-fold (0.56 log units) above the measured number, and the stated range ends above it.
By their numbers in this assay, from the lowest: compound 2; then compound 4; then compound 3. At a limit, above all of these: compound 1.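

In this assay, a 2.7-fold lower number from compound 3 to compound 4 (0.43 log units; beyond the scatter) shows that this position responds to a change between two aryl groups that both lack the 3-hydroxy-4-methoxyphenyl substitution, which the within-scatter floor between compound 1 and compound 3 could not show. Hydrogen in place of the fluoro of the 2-fluoro-4-methylphenyl gives an at least 5.1-fold lower number from compound 1 to compound 4 (0.71 log units; beyond the scatter), a step that is only a floor, as the entry for compound 1 is a limit: the limit of > 10000 nM in this assay, at which 1 of the 4 values shown sits. The 4-methylphenyl still leaves a clear gap to the 3-hydroxy-4-methoxyphenyl, with a 9.7-fold higher number from compound 2 to compound 4 (0.99 log units; beyond the scatter), so the gain at this position closes only part of the distance to the best number here.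

The step between compound 3 and compound 4 moves both the substituent and its place on the ring, so a 4-fluorophenyl or 3-methylphenyl would be needed to separate the two. Among the compounds shown, the hydroxy and the methoxy of the 3-hydroxy-4-methoxyphenyl also remain unseparated, and a 3-hydroxyphenyl, a 4-methoxyphenyl or a 3-aminophenyl at this aromatic carbon would address that.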